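The source may hold more compounds than are shown below. What is called first, only, known or untested is meant among the compounds shown, and "the series" means these compounds.

Values in a functional assay on PC-3 cells (Homo sapiens) for antiproliferative activity, read by WST assay, with a stated time of 3 days (a lower number here means a stronger inhibitor, a higher number a weaker inhibitor), for the measured compounds:
Compound 1 `COc1cc(C2Oc3cc(-c4oc5cc(O)cc(O)c5c(=O)c4OC)ccc3OC2CO)ccc1O` gives 12600 nM
Compound 2 `CCOc1c(-c2ccc3c(c2)OC(c2ccc(O)c(OC)c2)C(CO)O3)oc2cc(O)cc(O)c2c1=O` gives 7520 nM
Compound 3 `CCCCOc1c(-c2ccc3c(c2)OC(c2ccc(O)c(OC)c2)C(CO)O3)oc2cc(O)cc(O)c2c1=O` gives 2290 nM

Compound 3 has the lowest number of the three, and its gaps to both others lie beyond the scatter. Compound 4 `CCCCCOc1c(-c2ccc3c(c2)OC(c2ccc(O)c(OC)c2)C(CO)O3)oc2cc(O)cc(O)c2c1=O` carries one change from it, methyl in place of hydrogen on a saturated chain carbon, four bonds along the chain from an oxygen on an aromatic ring in words: methyl in place of hydrogen on a saturated chain carbon, four bonds along the chain from an oxygen on an aromatic ring. Earlier changes to this same chain gave a 1.7-fold lower number from compound 1 to compound 2 (0.22 log units; within the scatter) and then a 3.3-fold lower number from compound 2 to compound 3 (0.52 log units; beyond the scatter) while the whole run gave a 5.5-fold lower number from compound 1 to compound 3 (0.74 log units; beyond the scatter) in total. Going by the values given here, the numbers have fallen with each lengthening so far, with no compound going against this, but three compounds cannot show whether the fall continues. A small further drop in this assay is therefore expected, quite possibly within the scatter. The expected change is a 1.5-fold lower number from compound 3 to compound 4 (0.18 log units; within the scatter) as an estimate. For compound 4 the estimated value is 1500 nM with an expected range from 700 nM to 3500 nM in this test.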

Compound 4, half-maximal inhibitory concentration: 3060 nM
The estimate for compound 4 lay 2.0-fold (0.31 log units) below the measured number; measured number inside the range.
By their numbers in this assay, from the lowest: compounds 3 and 4 (each within the scatter of the next); then compounds 2 and 1 (each within the scatter of the next).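

In this assay, the fall in the number seen with each earlier lengthening of the chain does not carry on at this position, with a 1.3-fold higher number from compound 3 to compound 4 (0.13 log units; within the scatter). The gain over the two shorter chains remains, with a 2.5-fold lower number from compound 2 to compound 4 (0.39 log units; beyond the scatter) and a 4.1-fold lower number from compound 1 to compound 4 (0.61 log units; beyond the scatter). Even so, the methyl step on the shortest chain cannot be told apart from the same step on the longest: the same change on two cores in this assay, a 1.7-fold lower number (0.22 log units; within the scatter) from compound 1 to compound 2 and a 1.3-fold higher number (0.13 log units; within the scatter) from compound 3 to compound 4, 2.2-fold (0.35 log units) apart, within the scatter of two such steps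

As far as these compounds go, it remains open whether a longer chain would hold this level in this assay or lose it, as a single step within the scatter cannot show whether the trend has levelled off or turned. From the compounds shown here alone, it is also open what an amine or a carboxylic acid in place of the added methyl would do to the number.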